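Hydroxamic Acid in Place of Methylamide on Second Core

This account rests on a few compounds, and the source may have more. Where it says the series, first, only, none or still open, it means among the compounds named here.

Compound 1, `CNC(=O)CCCCCCCn1nc(-c2cnc3[nH]ccc3c2)c2c(N)ncnc21`, gives 16300 nM in a functional assay on Hep 3B2 cells (Homo sapiens) for inhibition, read by MTT assay, with a stated time of 72 h; on this read-out higher numbers stand for weaker inhibition and lower numbers for stronger inhibition.
Compound 2, `Nc1ncnc2c1c(-c1cnc3[nH]ccc3c1)nn2CCCCCCC(=O)NO`, gives 26300 nM in this assay.
Compound 3, `CNC(=O)CCCCCCCn1nc(-c2ccc3oc(N)nc3c2)c2c(N)ncnc21`, gives 10300 nM in this assay.

Compound 2 differs from compound 1 by hydroxycarbamoyl in place of (methylcarbamoyl)methyl on a saturated chain carbon, six bonds along the chain from an aromatic nitrogen. This change produced a 1.6-fold higher number from compound 1 to compound 2 (0.21 log units; within the scatter), so the two numbers cannot be told apart. Compound 3 differs from compound 1 in its core by a group of 10 heavy atoms (7 carbon, 2 nitrogen, 1 oxygen; one five-membered aromatic ring with 2 hetero atoms, one six-membered aromatic ring of carbon only) in place of a group of 9 heavy atoms (7 carbon, 2 nitrogen; one five-membered aromatic ring with 1 hetero atom, one six-membered aromatic ring with 1 hetero atom), on an aromatic carbon, and that change produced a 1.6-fold lower number from compound 1 to compound 3 (0.20 log units; within the scatter). Compound 3 and compound 2 stand further apart, and their two values lie beyond the usual scatter of each other.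

Compound 4, `Nc1nc2cc(-c3nn(CCCCCCC(=O)NO)c4ncnc(N)c34)ccc2o1`, has not yet been measured in this assay. It differs from compound 3 by hydroxycarbamoyl in place of (methylcarbamoyl)methyl on a saturated chain carbon, six bonds along the chain from an aromatic nitrogen, the same change that took compound 1 to compound 2, at the same place in the chain. Because that earlier change gave only a 1.6-fold higher number from compound 1 to compound 2 (0.21 log units; within the scatter), the expected step here is a 1.6-fold higher number from compound 3 to compound 4 (0.19 log units; within the scatter), resting on one pair alone. Compound 4 is therefore estimated at 16000 nM, with a likely range from 7000 nM to 40000 nM.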

Compound 4, half-maximal inhibitory concentration: 14000 nM
The estimate for compound 4 lay 1.1-fold (0.06 log units) above the measured number; the range from low to high includes it.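

Putting hydroxycarbamoyl in place of (methylcarbamoyl)methyl gives a 1.4-fold higher number from compound 3 to compound 4 (0.13 log units; within the scatter) in this assay, and this step matches the one seen on the other core: the same change on two cores in this assay, a 1.6-fold higher number (0.21 log units; within the scatter) from compound 1 to compound 2 and a 1.4-fold higher number (0.13 log units; within the scatter) from compound 3 to compound 4, 1.2-fold (0.07 log units) apart, within the scatter of two such steps. The change of core, read with hydroxycarbamoyl on the chain, gives a 1.9-fold lower number from compound 2 to compound 4 (0.27 log units; within the scatter), and it also matches its earlier counterpart: the same change on two cores in this assay, a 1.6-fold lower number (0.20 log units; within the scatter) from compound 1 to compound 3 and a 1.9-fold lower number (0.27 log units; within the scatter) from compound 2 to compound 4, 1.2-fold (0.07 log units) apart, within the scatter of two such steps. Within the data shown here, on these two cores, then, the chain change carries over with no sign that the core alters it, but each step is small enough to lie within the scatter, so this shows only that the change has no clear effect on either core, not that a larger effect would carry over in the same way.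

The four compounds leave open whether a carboxylic acid at the end of the chain, or a longer chain, would also behave alike on both cores. They also leave open whether the same agreement would hold on a third core.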